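The source may hold more compounds than are shown below. What is called first, only, known or untested is meant among the compounds shown, and "the series" means these compounds.

In a functional assay on CHO cells for agonist activity at Melanocortin receptor 4 (Homo sapiens), read by cAMP accumulation (a lower number here means that less compound is needed, a higher number that more compound is needed for the effect), compound 1 `Cc1ccc(N2CCN(C(=O)[C@@H]3CN(C4CCOCC4)C[C@H]3c3ccc(Cl)cc3)CC2)c([C@@H](NC(=O)CN)C(C)C)c1` gives 9.1 nM, the lowest of the three numbers recorded. Compound 3 `CC(C)[C@H](NC(=O)CCN(C)C)c1cccc(F)c1N1CCN(C(=O)[C@@H]2CN(C(C)C)C[C@H]2c2ccc(Cl)cc2)CC1` gives 20 nM in this assay, and compound 2 `CC(=O)N1C[C@@H](C(=O)N2CCN(c3ccc(C)cc3[C@@H](NC(=O)CCN(C)C)C(C)C)CC2)[C@H](c2ccc(Cl)cc2)C1` gives 44 nM; both of these lie beyond the scatter from the number of compound 1, yet each differs from it in several places at once, so no single change can be read from those gaps. The compound still to be measured, compound 4 `CNCC(=O)N[C@H](c1cc(C)ccc1N1CCN(C(=O)[C@@H]2CN(C3CCOCC3)C[C@H]2c2ccc(Cl)cc2)CC1)C(C)C`, keeps everything in compound 1 except one point: methyl in place of hydrogen on an amine nitrogen. Among the measured compounds shown here, no pair of measured compounds here differs by that change alone, so there is no measured step to lean on. Exchanging one hydrogen for a methyl group on an amine nitrogen is a small alteration, and the expected step from compound 1 to compound 4 in this assay is a 1.1-fold higher number from compound 1 to compound 4 (0.04 log units; within the scatter), a shift that is expected to stay within the usual scatter. Compound 4 is therefore estimated at 10 nM in this assay, with a likely range from 4 nM to 25 nM.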

Compound 4, half-maximal effective concentration: 19 nM
The estimate for compound 4 lay 1.9-fold (0.28 log units) below the measured number, and the stated range covers the measured number.
By their numbers in this assay, from the lowest: compound 1; then compounds 4 and 3 (each within the scatter of the next); then compound 2.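

Among the compounds shown here, compound 1 and compound 4 form the first pair here that differs in one place only, so the effect of this change can now be read directly: methyl in place of hydrogen on the amine nitrogen gives a 2.1-fold higher number from compound 1 to compound 4 (0.32 log units; beyond the scatter) in this assay. Even this one added carbon, with no ring and no charge, moves the number by a modest but real step. The change raises the amount of compound needed without removing agonist activity, and nothing shown here explains the size of this step.

As far as these compounds go, whether an ethyl or cyclopropyl group on this nitrogen would raise the number further remains open. Compound 2 and compound 3 carry a longer chain, but they differ from compound 1 in several places, so they cannot settle this.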